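Extending the Amine Tail of Compound 1

The compounds below may be only part of what the source reports. "The series", "measured", "known", "first", "only" and "open" are said of these compounds alone.

Compound 1 `CN(C)CCNc1nc(-c2ccc(NC(=O)Nc3ccccc3F)cc2)nc2ccsc12`: 410 nM
Compound 2 `Cc1ccc(NC(=O)Nc2ccc(-c3nc(NCCN(C)C)c4sccc4n3)cc2)cc1`: 1880 nM

In a functional assay on NCI-H460 cells (Homo sapiens) for cytotoxicity, read by MTT assay, with a stated time of 72 h (a lower number here means a stronger inhibitor, a higher number a weaker inhibitor), compound 1 gives 410 nM, the lowest of the two numbers; the nearest, compound 2, gives 1880 nM, and a 4.6-fold higher number from compound 1 to compound 2 (0.66 log units; beyond the scatter). Compound 3 `CCN(CC)CCNc1nc(-c2ccc(NC(=O)Nc3ccccc3F)cc2)nc2ccsc12` differs from compound 1 by diethylamino in place of dimethylamino on a saturated chain carbon, two bonds along the chain from a nitrogen on an aromatic ring. Going by the values given here, the only measured step concerns the group on the amide-type nitrogen, not the amine tail, so no comparison bears directly on this change. Compound 3 is therefore expected to stay close to compound 1, with a 1.1-fold higher number from compound 1 to compound 3 (0.04 log units; within the scatter) not beyond the scatter. The estimate for compound 3 is 450 nM, within 200 nM to 1000 nM.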

Compound 3, half-maximal inhibitory concentration: 430 nM
For compound 3 the middle estimate is 1.0-fold (0.02 log units) above the measured one, and the stated range covers the measured number.
By their numbers in this assay, from the lowest: compounds 1 and 3 (each within the scatter of the next); then compound 2.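

Up to this point only the amide-type nitrogen had been varied, and the amine tail had not been tested. In this assay, diethylamino in place of dimethylamino gives a 1.0-fold higher number from compound 1 to compound 3 (0.02 log units; within the scatter) and so shows that this end of the tail accepts the larger of these two groups without a step beyond the scatter. No evidence at hand accounts for this result. From the compounds shown here alone, it remains open how a ring amine such as pyrrolidine or morpholine, a longer chain, or a hydroxyl group in place of the amine would read at this position.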